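The source may hold more compounds than are shown below. What is called first, only, known or untested is meant among the compounds shown, and "the series" means these compounds.

Of the compounds shown here, three built on one shared core have been tested in a functional assay on A549 cells (Homo sapiens) for inhibition, read by MTT assay, with a stated time of 48 h; on this read-out higher numbers stand for weaker inhibition and lower numbers for stronger inhibition. Compound 1 `C/C(=N\NC(=O)c1cc(-c2ccccc2)nn1Cc1ccc(C(C)(C)C)cc1)c1cc(C)ccc1O` gives 6100 nM. Compound 2 `C/C(=N\NC(=O)c1cc(-c2ccccc2)nn1Cc1ccc(C(C)(C)C)cc1)c1cc(Cl)ccc1O` gives 2770 nM. The step is a 2.2-fold lower number from compound 1 to compound 2 (0.34 log units; beyond the scatter), and the change behind it is chloro in place of methyl on an aromatic carbon. Compound 3 `C/C(=N\NC(=O)c1cc(-c2ccc(Cl)cc2)nn1Cc1ccc(C(C)(C)C)cc1)c1cc(C)ccc1O` gives 2490 nM. Here the step is a 2.4-fold lower number from compound 1 to compound 3 (0.39 log units; beyond the scatter), and the two cores differ by chloro in place of hydrogen on an aromatic carbon. Compound 4 `C/C(=N\NC(=O)c1cc(-c2ccc(Cl)cc2)nn1Cc1ccc(C(C)(C)C)cc1)c1cc(Cl)ccc1O` has not yet been measured. It differs from compound 3 by chloro in place of methyl on an aromatic carbon, the same change, at the same place, as from compound 1 to compound 2. Because that change once gave a 2.2-fold lower number from compound 1 to compound 2 (0.34 log units; beyond the scatter), a similar step is expected from compound 3 to compound 4, estimated as a 2.2-fold lower number from compound 3 to compound 4 (0.34 log units; beyond the scatter). Compound 4 is therefore expected to give about 1150 nM, most likely between 600 nM and 2300 nM.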

Compound 4, half-maximal inhibitory concentration: 280 nM
Compound 4: the middle estimate sits 4.1-fold (0.61 log units) above what was measured; the measured number lies below the stated range.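

In this assay, chloro in place of methyl gave an 8.9-fold lower number from compound 3 to compound 4 (0.95 log units; beyond the scatter), so the size of this step did not carry over from one core to the other: the same change on two cores in this assay, a 2.2-fold lower number (0.34 log units; beyond the scatter) from compound 1 to compound 2 and an 8.9-fold lower number (0.95 log units; beyond the scatter) from compound 3 to compound 4, 4.0-fold (0.61 log units) apart, beyond the scatter of two such steps. The second change, chloro in place of hydrogen on an aromatic carbon, gave a 9.9-fold lower number from compound 2 to compound 4 (1.00 log units; beyond the scatter), and it too differed in size between the cores: the same change on two cores in this assay, a 2.4-fold lower number (0.39 log units; beyond the scatter) from compound 1 to compound 3 and a 9.9-fold lower number (1.00 log units; beyond the scatter) from compound 2 to compound 4, 4.0-fold (0.61 log units) apart, beyond the scatter of two such steps. Among these compounds, each change lowered the number on both cores, and the two chloro groups together did more than the single steps add up to, but these four compounds show this for one pair of changes only and do not show why it happens.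

The compounds shown leave open whether a fluoro, bromo or methoxy group in place of either chloro would also give a larger step when the other chloro is present.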